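Two Weak Anilides and a Difluorophenyl Newcomer

The compounds below may be only part of what the source reports. "The series", "measured", "known", "first", "only" and "open" are said of these compounds alone.

Compound 2 `CCOC1=C(/C(C)=N/OCC(=O)Nc2ccc(C(F)(F)F)cc2)N(C)S(=O)(=O)c2ccccc21` is one of two closely related amides tested in a functional assay on THP-1 cells (Homo sapiens) for inhibition, read by ELISA, with stated times of 2 h and 48 h; on this read-out lower numbers stand for stronger inhibition and higher numbers for weaker inhibition. Its relative compound 1 `CCOC1=C(/C(C)=N/OCC(=O)Nc2ccc(OC)cc2)N(C)S(=O)(=O)c2ccccc21` gives only a limit in this assay, > 20000 nM. For the measured compounds named here, compound 2 gives 16700 nM, the only real number among the values shown. The step of an at least 1.1-fold lower number from compound 1 to compound 2 (0.07 log units; that floor lies within the scatter) cannot be read as a true gain, since compound 1 sits at the limit of > 20000 nM in this assay, at which 1 of the 2 values shown sits. The unmeasured compound 3 `CCOC1=C(/C(C)=N/OCC(=O)Nc2c(F)cccc2F)N(C)S(=O)(=O)c2ccccc21` differs from compound 2 by a single change: 2,6-difluorophenyl in place of 4-(trifluoromethyl)phenyl on an amide-type nitrogen. No measured step involves this change; the one step shown concerns trifluoromethyl in place of methoxy on an aromatic carbon and lies within the scatter. No step beyond the scatter is therefore expected in this assay, in either direction, and the estimate for compound 3 is 20000 nM (7000 nM to 60000 nM), an expected step of a 1.2-fold higher number from compound 2 to compound 3 (0.08 log units; within the scatter).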

Compound 3, half-maximal inhibitory concentration: > 20000 nM
Compound 3 gave a limit, no number (the forecaster's own chance of this, stated with the estimate: 50%); the middle value sits exactly at the limit.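

Placing 2,6-difluorophenyl on the amide-type nitrogen in place of 4-(trifluoromethyl)phenyl gives an at least 1.1-fold higher number from compound 2 to compound 3 (0.07 log units; that floor lies within the scatter), so this change brings no readable gain in this assay. The comparison of compound 1 with compound 3 cannot be read, as both values are limits and not numbers. With a third aryl group at this position, most of the series now rests on a limit and not on a number: the limit of > 20000 nM in this assay, at which 2 of the 3 values shown sit.

The compounds shown leave open whether any group on this nitrogen can give a value clearly stronger than that of compound 2 in this assay. A phenyl ring bearing an amine or a carboxylic acid, or a longer chain in place of the ring, could answer that.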